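Cytotoxicity of three related compounds on Vero cells

The source may report more compounds than this note shows. Statements on the series, on what has been measured and on what is new or still open speak of the compounds shown alone.

Compound 1 `COc1ccc2[nH]c(C(=O)N3CC(=O)N(Cc4ccccc4)[C@@H](N4CCC(Cc5ccccc5)CC4)C3)cc2c1` was tested in an ADME assay on Vero cells (Chlorocebus sabaeus) for cytotoxicity, with a stated time of 7 days; a lower number here means that less compound is tolerated, a higher number that more compound is tolerated. For compound 1 the result is a limit of the assay, > 30000 nM. Compound 2 `COc1ccc2[nH]c(C(=O)N3CC(=O)N(Cc4ccccc4)[C@@H](COc4ccc(F)cc4)C3)cc2c1` gives 33200 nM in this assay, the only plain number among these compounds, the other value being (the limit of > 30000 nM in this assay, at which 1 of the 2 values shown sits). Compound 3 `COc1ccc2[nH]c(C(=O)N3CC(=O)N(Cc4ccccc4)[C@@H](CN4CCC5(CCCC5)CC4)C3)cc2c1` differs from compound 2 by a group of 10 heavy atoms (9 carbon, 1 nitrogen; one five-membered non-aromatic ring of carbon only, one six-membered non-aromatic ring with 1 hetero atom) in place of a group of 8 heavy atoms (6 carbon, 1 oxygen, 1 fluorine; one six-membered aromatic ring of carbon only), on a saturated chain carbon bound to a saturated ring carbon. Among the compounds with values here, no measured step between compounds exists here, so the expectation rests on the two values alone. The step from compound 2 to compound 3 in this assay is expected to be a 1.1-fold lower number from compound 2 to compound 3 (0.04 log units; within the scatter), no larger than the usual scatter. Compound 3 is estimated at 30000 nM, between 12000 nM and 70000 nM.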

Compound 3, half-maximal cytotoxic concentration: 3600 nM
Compound 3: the middle estimate sits 8.3-fold (0.92 log units) above what was measured; the whole stated range lies above it.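

At this saturated chain carbon, the group placed there clearly matters in this assay: replacing 4-fluorophenoxy with the group carrying a five-membered carbon ring and a six-membered ring with one hetero atom gives a 9.2-fold lower number from compound 2 to compound 3 (0.96 log units; beyond the scatter). The cells therefore tolerate less of compound 3 than of compound 2. Nothing measured here gives a reason for this change. On these data alone, it remains open whether a small dimethylamino group at this place would also lower the number, or whether the larger two-ring group is needed.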